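The source may hold more compounds than are shown below. What is called first, only, known or untested is meant among the compounds shown, and "the series" means these compounds.

For the measured compounds named here, compound 1 `CC(C)(C)C(=O)N(CCCCCCN1C[C@H](O)[C@@H](O)[C@H](O)[C@H]1CO)C1CCCCC1` is the only compound with a measured number in an ADME assay on Huh-7 cells (Homo sapiens) for cytotoxicity, read by MTT assay; on this read-out higher numbers stand for lower toxicity in this test and lower numbers for higher toxicity in this test; in this assay compound 1 gives 500000 nM. Compound 2 `CC(C)(C)C(=O)N(CCCCCCN1C[C@H](O)[C@@H](O)[C@H](O)[C@H]1CO)C1CCCC1` is known only through a limit of this assay, > 500000 nM. The step of a number no lower from compound 1 to compound 2 (the limit leaves the size open) therefore cannot be sized, and its reading rests on (the limit of > 500000 nM in this assay, at which 1 of the 2 values shown sits).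

Compound 3 `CC(C)(C)C(=O)N(CCCCCCN1C[C@H](O)[C@@H](O)[C@H](O)[C@H]1CO)C1CCCCCC1` differs from compound 1 in that (cycloheptyl in place of cyclohexyl on an amide-type nitrogen). Going by the values given here, the only measured step that bears on it is the one from cyclohexyl to cyclopentyl, and that step gave no readable size. A ring one carbon larger is therefore expected to leave this assay where compound 1 stands, with a step of no change at the digits printed from compound 1 to compound 3 (within the scatter) that is not expected to exceed the scatter. For compound 3 the estimate in this assay is 500000 nM, with a range from 250000 nM to 1000000 nM.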

Compound 3, half-maximal cytotoxic concentration: > 500000 nM
Compound 3 was reported as a limit; the forecaster's own chance of this, stated with the estimate: 50%; the middle value sits exactly at the limit.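

In this assay, compound 3 is reported only as a limit, > 500000 nM. The change reads as a number no lower from compound 1 to compound 3 (the limit leaves the size open), so on the amide-type nitrogen both the ring one carbon smaller and the ring one carbon larger than cyclohexyl now give a result no lower than that of compound 1. The size of neither step from compound 1 can be read, nor can the step between the two limits, and the ring series gives no graded trend: the limit of > 500000 nM in this assay, at which 2 of the 3 values shown sit.

The compounds shown leave open whether any group on this nitrogen would give a measured number well under this limit in this assay. A phenyl or benzyl group, an open-chain tert-butyl group, or a cyclohexyl ring carrying an amine or a carboxylic acid would each test this.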